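Stability expectation for the 2-oxoimidazolidin-1-yl analogue

This account rests on a few compounds, and the source may have more. Where it says the series, first, only, none or still open, it means among the compounds named here.

Within the data shown here, compound 3 `COCC(=O)NC1CCN(c2nc(C)c3cc(NC(=O)/C=C/c4ccc(OC(F)(F)F)cc4)ccc3n2)CC1` gives 58% in an ADME assay on microsomes from liver (Homo sapiens) for metabolic stability, with a stated time of 30 min (a higher number here means that more of the compound is left, a lower number that less of the compound is left), the lower of the two numbers measured so far; compound 1 `Cc1nc(N2CCC(N3CCOC3=O)CC2)nc2ccc(NC(=O)/C=C/c3ccc(OC(F)(F)F)cc3)cc12` gives 85% in this assay. For compound 2 `Cc1nc(NCCNC(=O)C2CC2)nc2ccc(NC(=O)/C=C/c3ccc(OC(F)(F)F)cc3)cc12` the entry in this assay reads "not determined" (no result reported). Among the measured compounds shown here, the only measured step that touches this position is a number 27 percentage points lower from compound 1 to compound 3 (beyond the scatter). Compound 4 `Cc1nc(N2CCC(N3CCNC3=O)CC2)nc2ccc(NC(=O)/C=C/c3ccc(OC(F)(F)F)cc3)cc12` differs from compound 3 by 2-oxoimidazolidin-1-yl in place of ((methoxymethyl)carbonyl)amino on a saturated ring carbon, so a five-membered ring group stands here again, as in compound 1, in place of the open amide of compound 3. Because compound 1 gives 85% and a number 27 percentage points lower from compound 1 to compound 3 (beyond the scatter) was beyond the scatter, a rise back toward that level is expected for compound 4, roughly a number 17 percentage points higher from compound 3 to compound 4 (beyond the scatter). Compound 4 is estimated at 75%, with a range from 55% to 90%.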

Compound 4, percent of the compound remaining: 83%
Estimate against measurement, compound 4: 8 percentage points below; measured number inside the range.
By their numbers in this assay, from the lowest: compound 3; then compounds 4 and 1 (each within the scatter of the next).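

In this assay, among these compounds, the change to 2-oxoimidazolidin-1-yl gives a number 25 percentage points higher from compound 3 to compound 4 (beyond the scatter) and so recovers the loss seen in the only earlier step at this position. Exchanging the five-membered ring of compound 1 for that of compound 4 gives a number 2 percentage points lower from compound 1 to compound 4 (within the scatter) and so separates neither ring from the other here. The low number is therefore not specific to replacing the 2-oxo-1,3-oxazolidin-3-yl ring, and it stands so far with the open ((methoxymethyl)carbonyl)amino group of compound 3 alone.

From the compounds shown here alone, whether an open-chain urea or a simple amine at this place would sit with the two ring compounds or with compound 3 remains open. Nothing shown speaks to the reason for the gap between the ring compounds and the open amide.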